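Fluoro for carbamoyl on a compound without a measured number

A few compounds are considered here, and "the series" means these few. Any claim that something is new, unique, unknown or untested is made for them only; others in the source may bear on it.

Measured compounds:
compound 1, `CCCNS(=O)(=O)c1ccc(Nc2ncc3c(n2)N(C2CCCC2)[C@H](CC)C(=O)N3C)cc1`, 278 nM
compound 2, `CCC1C(=O)N(C)c2cnc(-n3ccc4cc(C(N)=O)ccc43)nc2N1c1ccn(C)n1`, "not active" (no number reported)

In a functional assay on Huh-7 cells (Homo sapiens) for antiproliferative activity, read by CCK-8 assay, with a stated time of 72 h (a higher number here means a weaker inhibitor of growth, a lower number a stronger inhibitor of growth), compound 1 gives 278 nM. In this assay compound 2 gives "not active" (no number reported), with no number reported, so compound 2 has no place on a numerical scale here; it is simply the one of the two measured compounds that carries no value, while compound 1 is the one that does. The two share no single-point relation, so nothing further is read from the pair.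

Compound 3, `CCC1C(=O)N(C)c2cnc(-n3ccc4cc(F)ccc43)nc2N1c1ccn(C)n1`, differs from compound 2 in one place: fluoro in place of carbamoyl on an aromatic carbon.

Going by the values given here, no step between measured compounds exists, and compound 2 has no number, so the size of the step to compound 3 cannot be set against the scatter; a weak result is expected for compound 3 because compound 2 gave "not active" (no number reported). The estimate for compound 3 in this assay is 8000 nM, expected between 1500 nM and 40000 nM.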

Compound 3, concentration for 50% growth inhibition: "not active" (no number reported)
For compound 3 the study gives words and no number; no gap can be computed for the estimate.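

Compound 2 and compound 3 both carry words and no number, so no step can be read between them. The compounds shown leave open how fluoro and carbamoyl at this place compare in growth inhibition. No measurement here bears on a cause for this result.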